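The source may report more compounds than this note shows. Statements on the series, on what has been measured and on what is new or still open speak of the compounds shown alone.

Three quinolone carboxylic acids carrying a biphenylmethyl group on the ring nitrogen were examined in an assay on isolated protein for inhibition of DNA topoisomerase 1 (Homo sapiens), with a stated time of 15 min; a lower number here means a stronger inhibitor, a higher number a weaker inhibitor. Compound 1 `COc1c(N2CC[C@@H](CN)C2)c(F)cc2c(=O)c(C(=O)O)cn(Cc3ccc(-c4ccccc4)cc3)c12` gives 26000 nM. Compound 2 `CNCCCNc1c(F)cc2c(=O)c(C(=O)O)cn(Cc3ccc(-c4ccccc4)cc3)c2c1OC` gives 101000 nM. Compound 3 `CNCCCNc1cc2c(cc1F)c(=O)c(C(=O)O)cn2Cc1ccc(-c2ccccc2)cc1` gives 63600 nM.

Two of these differ in one place only from compound 2. The difference between compound 2 and compound 1 is 3-(aminomethyl)pyrrolidin-1-yl in place of (3-(methylamino)propyl)amino on an aromatic carbon and it brings a 3.9-fold lower number from compound 2 to compound 1 (0.59 log units; beyond the scatter). The difference between compound 2 and compound 3 is hydrogen in place of methoxy on an aromatic carbon, and the step of a 1.6-fold lower number from compound 2 to compound 3 (0.20 log units; within the scatter) lies within the scatter, so no order between compound 2 and compound 3 is claimed here.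

Compound 4 `NC[C@@H]1CCN(c2cc3c(cc2F)c(=O)c(C(=O)O)cn3Cc2ccc(-c3ccccc3)cc2)C1` has not yet been measured in this assay. It differs from compound 3 by 3-(aminomethyl)pyrrolidin-1-yl in place of (3-(methylamino)propyl)amino on an aromatic carbon. Within the data shown here, this is the same kind of change as the one from compound 2 to compound 1, not the same change: in the pair of compound 2 and compound 1 the place is also ortho to a methoxy group, whereas in compound 3 and compound 4 no methoxy group stands there. Among the measured compounds shown here, with only one earlier example of this kind of change, the expectation for compound 4 rests on that single step. For the measured compounds named here, compound 4 is therefore expected to show a 3.7-fold lower number from compound 3 to compound 4 (0.57 log units; beyond the scatter), close in size to the step seen from compound 2 to compound 1, because a 3.9-fold lower number from compound 2 to compound 1 (0.59 log units; beyond the scatter) is the only guide available. The estimate for compound 4 in this assay is 17000 nM, with a range expected from 7000 nM to 45000 nM.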

Compound 4, half-maximal inhibitory concentration: 15600 nM
Estimate against measurement, compound 4: 1.1-fold (0.04 log units) above, and the stated range covers the measured number.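

In this assay, among these compounds, 3-(aminomethyl)pyrrolidin-1-yl in place of (3-(methylamino)propyl)amino gives a 4.1-fold lower number from compound 3 to compound 4 (0.61 log units; beyond the scatter), and the change carries over between the methoxy-bearing core and the core with hydrogen at that place with no measurable difference in size: the same change on two cores in this assay, a 3.9-fold lower number (0.59 log units; beyond the scatter) from compound 2 to compound 1 and a 4.1-fold lower number (0.61 log units; beyond the scatter) from compound 3 to compound 4, 1.0-fold (0.02 log units) apart, within the scatter of two such steps Seen the other way round, hydrogen in place of methoxy gives a 1.7-fold lower number from compound 1 to compound 4 (0.22 log units; within the scatter), so no order is claimed between these two compounds, and this step also reads alike with either side chain: the same change on two cores in this assay, a 1.6-fold lower number (0.20 log units; within the scatter) from compound 2 to compound 3 and a 1.7-fold lower number (0.22 log units; within the scatter) from compound 1 to compound 4, 1.0-fold (0.02 log units) apart, within the scatter of two such steps Together the four compounds show that, in this small set, the two changes behave independently of each other, but they cover only one pair of side chains and two closely related cores, so they do not show that the step would carry over to other cores, nor do they explain why it occurs.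

The compounds shown leave open whether the step would hold with an ethoxy group or a chlorine in place of methoxy, or with a piperazine or the mirror-image form of the pyrrolidine as the side chain. They also leave open how it would fare with a plain benzyl group on the ring nitrogen, or with an amide in place of the carboxylic acid.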